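Lactam nitrogen substituent in the alkyne series

The source may report more compounds than this note shows. Statements on the series, on what has been measured and on what is new or still open speak of the compounds shown alone.

The series shares one core; compound 1 `Cc1ccccc1C#Cc1ccc2c(n1)CCN(C)C2=O`, compound 2 `Cc1cccc(C#Cc2ccc3c(n2)CCN(C)C3=O)c1` and compound 3 `CN1CCc2nc(C#Cc3ccccn3)ccc2C1=O` differ only in the aryl group on the triple-bonded carbon. In an assay on HEK293 cells for displacement of a labelled ligand from metabotropic glutamate receptor 5 (Homo sapiens), with a stated time of 2 h (on this read-out higher numbers stand for weaker inhibition and lower numbers for stronger inhibition), compound 2 gives 820 nM, the lower of the two numbers shown. Compound 3 gives 6240 nM, and a 7.6-fold higher number from compound 2 to compound 3 (0.88 log units; beyond the scatter). For compound 1 the assay reports only a limit, > 32000 nM (the limit of > 32000 nM in this assay, at which 1 of the 3 values shown sits). From there an at least 39-fold lower number from compound 1 to compound 2 (1.59 log units; beyond the scatter) and an at least 5.1-fold lower number from compound 1 to compound 3 (0.70 log units; beyond the scatter).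

Compound 4 `Cc1cccc(C#Cc2ccc3c(n2)CCN(C(C)C)C3=O)c1` differs from compound 2 by isopropyl in place of methyl on an amide-type nitrogen in a ring. Going by the values given here, none of the measured steps touches the amide-type nitrogen; all concern the aryl on the triple bond, so no step bears on this change. For compound 4 the expectation is a step no larger than the scatter, a 1.2-fold higher number from compound 2 to compound 4 (0.09 log units; within the scatter). Compound 4 is therefore estimated at 1000 nM, within 350 nM to 3000 nM.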

Compound 4, inhibition constant: 510 nM
Beside the measured number, compound 4's estimate is 2.0-fold (0.29 log units) above it, within the range that was stated.
By their numbers in this assay, from the lowest: compounds 4 and 2 (each within the scatter of the next); then compound 3. At a limit, above all of these: compound 1.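

On the amide-type nitrogen in a ring, the change from methyl to isopropyl gives, in this assay, a 1.6-fold lower number from compound 2 to compound 4 (0.21 log units; within the scatter). With 3-methylphenyl held on the triple-bonded carbon, this nitrogen therefore carries isopropyl as well as methyl with no change beyond the scatter, unlike the aryl changes seen so far. Nothing measured here speaks to the reason for this step.

Open, as far as these compounds go, is whether a longer chain, a benzyl group or an amine-bearing chain on this nitrogen keeps the number in range. Also open, from the compounds shown here alone, is whether isopropyl behaves alike with pyridin-2-yl on the triple bond.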